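Cytotoxicity notes on a bis(trifluoromethyl)benzoyl piperidine amide series

This account rests on a few compounds, and the source may have more. Where it says the series, first, only, none or still open, it means among the compounds named here.

Measured so far:
compound 1 `O=C(Nc1cccc([N+](=O)[O-])c1)C1CCCN(C(=O)c2cc(C(F)(F)F)cc(C(F)(F)F)c2)C1` gives 9% in an ADME assay on PC-3 cells (Homo sapiens) for cytotoxicity, read by WST assay, tested at 100 uM; on this read-out higher numbers stand for more inhibition at the one concentration tested (going by the name of the read-out) and lower numbers for less inhibition
compound 2 `COc1cccc(NC(=O)C2CCCN(C(=O)c3cc(C(F)(F)F)cc(C(F)(F)F)c3)C2)c1` gives 0% in this assay

Compound 2 stands lowest of the two numbers in this assay; its nearest neighbour is compound 1. Going by the values given here, the single measured step, a number 9 percentage points lower from compound 1 to compound 2 (within the scatter), lies within the scatter, so the two compounds cannot be ordered on these numbers.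

Compound 3 `O=C(Nc1ccc(Cl)cn1)C1CCCN(C(=O)c2cc(C(F)(F)F)cc(C(F)(F)F)c2)C1` is unmeasured. It differs from compound 2 in one place: 5-chloropyridin-2-yl in place of 3-methoxyphenyl on an amide-type nitrogen. Among the compounds with values here, the only measured step bears on it loosely, since it also changes the aryl group on the amide-type nitrogen, but it exchanged one substituent on an aromatic carbon, whereas here the whole 3-methoxyphenyl leaves and 5-chloropyridin-2-yl enters. Within the data shown here, with both measured numbers low and the one step within the scatter, the expected step in this assay is a number 4 percentage points higher from compound 2 to compound 3 (within the scatter), none beyond the scatter. Compound 3 is therefore estimated at 4%, with a range from -8% to 18%.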

Compound 3, a percentage reported as inhibition, at one concentration (the size of the read-out at that concentration, not a potency): 0%
Estimate against measurement, compound 3: 4 percentage points above, within the range that was stated.
By their numbers in this assay, from the lowest: compounds 2, 3 and 1 (each within the scatter of the next).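

On the amide-type nitrogen, the earlier step exchanged only one substituent on an aromatic carbon, whereas here the whole aryl group is replaced: in this assay 5-chloropyridin-2-yl in place of 3-methoxyphenyl gives no change at the digits printed from compound 2 to compound 3 (within the scatter) and 5-chloropyridin-2-yl in place of 3-nitrophenyl gives a number 9 percentage points lower from compound 1 to compound 3 (within the scatter) in the same series. A ring hetero atom and a chlorine at this position therefore leave the read-out within the scatter of both earlier compounds, so the three aryl groups cannot be ordered. No measurement at hand accounts for these numbers.

Still open, going by these compounds, is whether a carboxylic acid or a dimethylamino chain in place of these aryl substituents would move the number in this assay beyond the scatter. The same question stands for the two trifluoromethyl groups on the benzoyl part, which all three compounds share, and for a replacement such as chlorine or nitrile there.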